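The source may report more compounds than this note shows. Statements on the series, on what has been measured and on what is new or still open speak of the compounds shown alone.

Of the compounds shown here, three sharing one core have been tested in a functional assay on MDA-MB-231 cells (Homo sapiens) for cytotoxicity, read by MTT assay; a lower number here means a stronger inhibitor, a higher number a weaker inhibitor. Compound 1 `COc1ccc(-c2cn(-c3ccc(OC)cc3OC)nn2)cc1` and compound 2 `COc1cc(-c2cn(-c3cc(OC)c(OC)c(OC)c3)nn2)cc(OC)c1OC` carry only methoxy groups on the two rings attached to the shared core. In this assay compound 1 gives > 10000 nM, which is a limit of the assay and not a number. Compound 2 gives > 10000 nM in this assay, again a limit rather than a number. Compound 3 `COc1ccc(-c2cn(-c3ccc(OC)c(OC)c3)nn2)cc1O` carries one hydroxy group in place of a methoxy group on one ring. In this assay compound 3 gives > 100 nM, which is also a limit and not a number. Where compound 3 stands can therefore only be said roughly: it sits at the limit of > 100 nM in this assay, at which 1 of the 3 values shown sits, whereas the other two sit at the limit of > 10000 nM in this assay, at which 2 of the 3 values shown sit, and no step between measured compounds can be counted from limits alone.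

Compound 4 `COc1ccc(-c2cn(-c3ccc(OC)c(O)c3)nn2)cc1O` has not yet been measured. It differs from compound 3 by hydrogen in place of methyl on an oxygen on an aromatic ring. Within the data shown here, no measured step shows what this change does in this assay, and none of the three compounds provides a number to start from. The step from compound 3 to compound 4 is expected to be a step that the limit leaves unreadable from compound 3 to compound 4, which is within the scatter. Compound 4 is expected to give about 3000 nM, with a likely range from 300 nM to 30000 nM, and a good chance that the assay again reports only a limit.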

Compound 4, half-maximal inhibitory concentration: > 10000 nM
Compound 4: only a limit was reported (the forecaster's own chance of this, stated with the estimate: 60%); at least 3.3-fold (0.52 log units) between middle value and limit.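

Among these compounds, compound 3 and compound 4 are both reported only as limits of the assay, and the change from methoxy to hydroxy between them gives no step that can be read. The compounds shown leave open what this change does in this assay, and where any of the four compounds would stand as an actual number.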